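A Bromo Group Added to Compound 3

The source may hold more compounds than are shown below. What is called first, only, known or untested is meant among the compounds shown, and "the series" means these compounds.

Within the data shown here, in a functional assay on MDA-MB-231 cells (Homo sapiens) for antiproliferative activity, read by sulforhodamine B assay, with a stated time of 72 h (a higher number here means a weaker inhibitor, a lower number a stronger inhibitor), compound 3 `O=C(/C=C/c1csc2ccccc12)c1ccccc1O` gives 5300 nM, the only true number so far. Compound 1 `COc1cc2occ(-c3csc4ccccc34)c(=O)c2cc1OC` reads > 10000 nM, which is a limit of the assay. Compound 2 `O=C(/C=C/c1csc2ccccc12)c1cccc(Cl)c1` reads > 10000 nM, also a limit. Compound 4 `O=C(/C=C/c1csc2ccccc12)c1cc(Br)ccc1O` changes compound 3 in one place, with bromo in place of hydrogen on an aromatic carbon, para to a hydroxy group: bromo in place of hydrogen on an aromatic carbon. Among the measured compounds shown here, no two measured compounds differ in just one place, so no measured step offers a guide. A small gain in potency in this assay, near the edge of the usual scatter, seems most likely. The expected change is a 1.8-fold lower number from compound 3 to compound 4 (0.25 log units; within the scatter). For compound 4 the estimated value is 3000 nM, with an expected range of 1000 nM to 9000 nM.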

Compound 4, half-maximal inhibitory concentration: 840 nM
Beside the measured number, compound 4's estimate is 3.6-fold (0.55 log units) above it; measured number below the stated range.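

In this assay, bromo in place of hydrogen on an aromatic carbon, para to a hydroxy group, gives a 6.3-fold lower number from compound 3 to compound 4 (0.80 log units; beyond the scatter). So this position accepts a bromo group with a real gain in potency, and the change is large enough to read clearly. This is the first comparison between two true numbers, which the earlier compounds could not offer: the limit of > 10000 nM in this assay, at which 2 of the 4 values shown sit.

The compounds shown leave open whether the gain is specific to bromo, or whether fluoro, methyl, methoxy or an amine at this position would match it. They also leave open whether the gain depends on the hydroxy group.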